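Chloro for Methyl in Aryl Hydroxamic Acids: Liver Cell Toxicity

The compounds below may be only part of what the source reports. "The series", "measured", "known", "first", "only" and "open" are said of these compounds alone.

The study compares three hydroxamic acids and one that remains to be tested. Compound 1 `Cc1cccc(C(=O)NO)c1` gives 340000 nM in an ADME assay on Huh-7 cells (Homo sapiens) for cytotoxicity, read by MTT assay, with a stated time of 72 h; on this read-out higher numbers stand for lower toxicity in this test and lower numbers for higher toxicity in this test. Compound 2 `O=C(NO)c1cccc(Cl)c1` gives 120000 nM in this assay, and compound 3 `Cc1ccc(C(=O)NO)c(Cl)c1` gives 140000 nM in this assay. The step of a 2.8-fold lower number from compound 1 to compound 2 (0.45 log units; beyond the scatter) comes from the change (chloro in place of methyl on an aromatic carbon). The values of compound 3 and compound 2 lie within the scatter of each other, whereas compound 3 and compound 1 differ beyond it; how the core of compound 3 differs from the core of compound 1 is not broken down here.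

Compound 4 `O=C(NO)c1ccc(Cl)cc1Cl` differs from compound 3 by chloro in place of methyl on an aromatic carbon. This is the same kind of change as that from compound 1 to compound 2, though the surroundings differ: in compound 3 the place is meta to a chloro group and para to a hydroxycarbamoyl group, while in compound 1 it is meta to a group of 4 heavy atoms. On that basis the step is expected to be a 2.5-fold lower number from compound 3 to compound 4 (0.41 log units; beyond the scatter), resting on the measured 2.8-fold lower number from compound 1 to compound 2 (0.45 log units; beyond the scatter). Compound 4 is therefore estimated to give 55000 nM, most likely between 25000 nM and 150000 nM, in this assay.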

Compound 4, half-maximal cytotoxic concentration: 140000 nM
Compound 4: middle estimate off by 2.5-fold (0.41 log units), on the low side; the measured number falls inside the stated range.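

In this assay, chloro in place of methyl on the core of compound 3 gives no change at the digits printed from compound 3 to compound 4 (within the scatter), whereas the same swap on the core of compound 1 gave a 2.8-fold lower number from compound 1 to compound 2 (0.45 log units; beyond the scatter). The size of this step therefore does not carry over intact from one core to the other: the same change on two cores in this assay, a 2.8-fold lower number (0.45 log units; beyond the scatter) from compound 1 to compound 2 and no change at the digits printed (within the scatter) from compound 3 to compound 4, 2.8-fold (0.45 log units) apart, beyond the scatter of two such steps This shows that, for these two pairs, the effect of the swap on this read-out depends on the core, but two pairs set no rule for the series, and they do not show which difference between the cores matters or why the step vanishes on the second one.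

The compounds shown leave open how the same swap behaves on cores bearing other groups, such as a methoxy group or an amine. They also leave open whether a bromo or trifluoromethyl group in the same place, or a carboxylic acid in place of the hydroxycarbamoyl group, would follow either step.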